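One Ring for Another on the Carbonyl Carbon

A few compounds are considered here, and "the series" means these few. Any claim that something is new, unique, unknown or untested is made for them only; others in the source may bear on it.

Three compounds were tested in a functional assay on MOLT-4 cells (Homo sapiens) for inhibition, read by MTT assay, with a stated time of 48 h; on this read-out lower numbers stand for stronger inhibition and higher numbers for weaker inhibition. Compound 2 `O=C(/C=C/c1ccc(Cl)cc1)c1ccc[nH]1` gives 22000 nM. Compound 3 `O=C(/C=C/c1ccc(Cl)cc1)c1ccco1` differs from it in one place furan-2-yl in place of 1H-pyrrol-2-yl on a carbonyl carbon and gives 23000 nM; the step of a 1.0-fold higher number from compound 2 to compound 3 (0.02 log units; within the scatter) shows that this exchange left the number essentially where it was.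

Compound 1 `O=C(/C=C/c1cccc([N+](=O)[O-])c1)c1ccc[nH]1` gives 22000 nM in this assay; how its core differs from that of compound 2 is not broken down here, but the two numbers agree at the digits given, and compound 3 sits within the scatter of both.

Compound 4 `O=C(/C=C/c1cccc([N+](=O)[O-])c1)c1ccco1` has not yet been measured. It relates to compound 1 exactly as compound 3 relates to compound 2 (furan-2-yl in place of 1H-pyrrol-2-yl on a carbonyl carbon), at the same place with the same surroundings, so it is the same change made a second time.

Because the measured version of this change a 1.0-fold higher number from compound 2 to compound 3 (0.02 log units; within the scatter) stayed within the scatter, the step of no change at the digits printed from compound 1 to compound 4 (within the scatter) is expected to be equally small. Compound 4 is therefore estimated at 22000 nM, most likely between 11000 nM and 45000 nM, a single earlier instance being the only basis for this expectation.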

Compound 4, half-maximal inhibitory concentration: 18000 nM
Estimate against measurement, compound 4: 1.2-fold (0.09 log units) above; low and high end bracket the measured number.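

In this assay, putting furan-2-yl in place of 1H-pyrrol-2-yl on a carbonyl carbon gives a 1.2-fold lower number from compound 1 to compound 4 (0.09 log units; within the scatter), so this second instance of the exchange, like the first, leaves the number within the usual scatter. Set side by side, the two instances agree, and the exchange behaves alike on these two cores: the same change on two cores in this assay, a 1.0-fold higher number (0.02 log units; within the scatter) from compound 2 to compound 3 and a 1.2-fold lower number (0.09 log units; within the scatter) from compound 1 to compound 4, 1.3-fold (0.11 log units) apart, within the scatter of two such steps. This shows that the near absence of an effect carried over from one core to the other, but it rests on just two pairs, all four numbers lie close together, and it cannot establish that the same would hold on other cores or in other assays, nor can it explain why the exchange matters so little.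

The compounds shown leave open whether another ring on the carbonyl carbon, such as thiophen-2-yl or phenyl, would give a similar number. They also leave open whether the exchange would stay this small on a core carrying an amine or a methoxy group in place of the chlorine or the nitro group.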